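Cyclopropyl in Place of Cyclopentyl on the Amine Nitrogen

This account rests on a few compounds, and the source may have more. Where it says the series, first, only, none or still open, it means among the compounds named here.

Compound 1 `O=C1C(NC2CCCC2)=CC(=O)c2c1nc1n2[C@H]2OC[C@@H](O)[C@H]2OC1` — in a functional assay on MGC-803 cells (Homo sapiens) for inhibition, read by sulforhodamine B assay (a higher number here means a weaker inhibitor, a lower number a stronger inhibitor), compound 1 gives > 16000 nM, a limit of the assay rather than a number.
Compound 2 `COc1ccccc1NC1=CC(=O)c2nc3n(c2C1=O)[C@H]1OC[C@@H](O)[C@H]1OC3` — in this assay compound 2 gives 1630 nM.
Compound 3 `COc1ccc(NC2=CC(=O)c3nc4n(c3C2=O)[C@H]2OC[C@@H](O)[C@H]2OC4)cc1` — in this assay compound 3 gives 1680 nM.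

Compound 1 thus stands in this assay only as the limit of > 16000 nM in this assay, at which 1 of the 3 values shown sits, with no number of its own. Among the measured compounds shown here, the single measured step, a 1.0-fold higher number from compound 2 to compound 3 (0.01 log units; within the scatter), exchanges one methoxyphenyl for another on the amine nitrogen and does not bear on a change of a saturated ring. Compound 4 `O=C1C(NC2CC2)=CC(=O)c2c1nc1n2[C@H]2OC[C@@H](O)[C@H]2OC1` arises from compound 1 by cyclopropyl in place of cyclopentyl on an amine nitrogen. For the measured compounds named here, with no step bearing on it, the expectation is a change of a number no higher from compound 1 to compound 4 (the limit leaves the size open), nothing beyond the scatter. Compound 4 is therefore estimated at 16000 nM in this assay, between 5000 nM and 50000 nM, most likely reported again only as a limit.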

Compound 4, half-maximal inhibitory concentration: > 4000 nM
Compound 4: no number, only a limit (the forecaster's own chance of this, stated with the estimate: 60%); the middle value is on the limit's open side.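

The step from compound 1 to compound 4 cannot be read: in this assay both compounds stand only as limits of the assay, not as numbers. The compounds shown leave open whether cyclopropyl or cyclopentyl on the amine nitrogen gives the stronger inhibitor.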